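Replacing naphthalen-1-yl with 4-(tert-butyl)phenyl on a sulfur

The compounds below may be only part of what the source reports. "The series", "measured", "known", "first", "only" and "open" are said of these compounds alone.

Measured in a functional assay on HeLa cells (Homo sapiens) for inhibition, read by CCK-8 assay, with a stated time of 72 h, tested at 2 uM; on this read-out higher numbers stand for more inhibition of growth at the one concentration tested and lower numbers for less inhibition of growth:
- compound 1 `Nc1ccccc1NC(=O)/C=C/c1ccc(CSc2ccc(Cl)cc2)cc1`: 1.94%
- compound 2 `Nc1ccccc1NC(=O)/C=C/c1ccc(CSc2cccc(F)c2)cc1`: 2.25%
- compound 3 `Nc1ccccc1NC(=O)/C=C/c1ccc(CSc2cccc3ccccc23)cc1`: 20.6%

Compound 3 stands highest of the three, clear of the others in a number 18.7 percentage points higher from compound 1 to compound 3 (beyond the scatter) and a number 18.4 percentage points higher from compound 2 to compound 3 (beyond the scatter). Compound 4 `CC(C)(C)c1ccc(SCc2ccc(/C=C/C(=O)Nc3ccccc3N)cc2)cc1` is still unmeasured. Its change is 4-(tert-butyl)phenyl in place of naphthalen-1-yl on a sulfur. Among the measured compounds shown here, no measured step involves 4-(tert-butyl)phenyl, so the evidence is indirect. The two phenyl-bearing compounds sit low, and a number 0.3 percentage points higher from compound 1 to compound 2 (within the scatter) separates them only within the scatter. A modest fall from compound 3 is therefore expected, though perhaps not all the way to compound 2 at 2.25%. The expected change is a number 11.6 percentage points lower from compound 3 to compound 4 (beyond the scatter). Compound 4 is estimated at 9%, with an expected range of 1% to 24%.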

Compound 4, percent growth inhibition at one concentration: 17.5%
The estimate for compound 4 lay 8.5 percentage points below the measured number; the range from low to high includes it.
By their numbers in this assay, from the lowest: compounds 1 and 2 (each within the scatter of the next); then compounds 4 and 3 (each within the scatter of the next).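

With 4-(tert-butyl)phenyl on the sulfur, a single aromatic ring does as well as the two rings of naphthalen-1-yl, with a number 3.1 percentage points lower from compound 3 to compound 4 (within the scatter); both groups have 10 heavy atoms. The same group stands clear of the smaller-looking substituted phenyl groups, with a number 15.3 percentage points higher from compound 2 to compound 4 (beyond the scatter) and a number 15.6 percentage points higher from compound 1 to compound 4 (beyond the scatter). No evidence is available to explain these differences.

Going by these compounds, it remains open whether an amine or a carboxylic acid in place of the tert-butyl would keep this level of growth inhibition. A longer alkyl chain there is equally untested by these compounds.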